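This account rests on a few compounds, and the source may have more. Where it says the series, first, only, none or still open, it means among the compounds named here.

Compound 1 `CCc1cc(S(=O)(=O)N2C[C@H](c3ccccc3)NC2=O)ccc1NC(=O)OC(C)C` gives 60 nM in a functional assay on HCT-116 cells (Homo sapiens) for cytotoxicity, read by MTT assay; on this read-out lower numbers stand for stronger inhibition and higher numbers for weaker inhibition. Compound 2 `CCc1cc(S(=O)(=O)N2C[C@H](c3ccccc3)NC2=O)ccc1NC(=O)NC(C)C` gives 60 nM in this assay. The step of no change at the digits printed from compound 1 to compound 2 (within the scatter) shows that putting isopropylamino in place of isopropoxy on the carbonyl carbon left the read-out unchanged, so compound 2 stands level with compound 1 within the scatter, and these two are all that has been measured.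

Compound 3 `CCc1cc(S(=O)(=O)N2C[C@H](c3ccccc3)NC2=O)ccc1NC(=O)c1ccc(N)cc1` differs from compound 2 in one place: 4-aminophenyl in place of isopropylamino on a carbonyl carbon. Going by the values given here, the only measured step that touches the same carbonyl carbon is no change at the digits printed from compound 1 to compound 2 (within the scatter), which was flat, but it swapped two small chain groups, whereas here an aromatic ring enters, so that flat step is only a loose guide. A modest step at most is expected, with no clear direction. Compound 3 is therefore expected to give about 100 nM in this assay, between 30 nM and 400 nM, an estimated step of a 1.7-fold higher number from compound 2 to compound 3 (0.22 log units; within the scatter).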

Compound 3, half-maximal inhibitory concentration: 460 nM
For compound 3 the middle estimate is 4.6-fold (0.66 log units) below the measured one, and the stated range ends below it.
By their numbers in this assay, from the lowest: compounds 1 and 2 (each within the scatter of the next); then compound 3.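

This position is not indifferent to what sits on the carbonyl carbon. Isopropoxy and isopropylamino read alike, but in this assay 4-aminophenyl in place of isopropylamino gives a 7.7-fold higher number from compound 2 to compound 3 (0.88 log units; beyond the scatter), and 4-aminophenyl in place of isopropoxy gives a 7.7-fold higher number from compound 1 to compound 3 (0.88 log units; beyond the scatter), so this position does respond to a change of group, with the number rising beyond the scatter once this aromatic ring stands on the carbonyl carbon. No information is at hand on what lies behind this rise.

As far as these compounds go, it remains open whether the ring itself or its amino group matters more, a question that a plain phenyl on the same carbonyl carbon would address. From the compounds shown here alone, it is also open how a longer chain, such as n-butylamino, or a saturated ring, such as cyclohexyl, would read at this position.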